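Pyrazolyl to pyrimidinyl on the amide nitrogen

This account rests on a few compounds, and the source may have more. Where it says the series, first, only, none or still open, it means among the compounds named here.

Measured so far:
compound 1 `Cc1ccc(OCC(=O)N(Cc2cccs2)C(C)C)cc1` 70 nM
compound 2 `Cc1ccc(OCC(=O)N(Cc2cccs2)c2cn[nH]c2)cc1` 1.4 nM

For the measured compounds named here, in an assay on HEK293 cells for agonist activity at transient receptor potential cation channel subfamily M member 8 (Homo sapiens), read by fluorescence and calcium flux, with a stated time of 15 min (a higher number here means that more compound is needed for the effect, a lower number that less compound is needed), compound 2 holds the lowest number of the two, with compound 1 the only neighbour and a step of a 50-fold lower number from compound 1 to compound 2 (1.70 log units; beyond the scatter) separating them. Compound 3 `Cc1ccc(OCC(=O)N(Cc2cccs2)c2ncccn2)cc1` is not yet measured. Its change from compound 2 is pyrimidin-2-yl in place of 1H-pyrazol-4-yl on an amide-type nitrogen. Going by the values given here, the one measured step that bears on this position is the exchange of an alkyl group for an aromatic ring, which gave a 50-fold lower number from compound 1 to compound 2 (1.70 log units; beyond the scatter); it shows the amide-type nitrogen tolerates an aromatic substituent well, but says nothing about exchanging one aromatic ring for another. Among the compounds with values here, with no step of that kind available, a modest rise in the number is expected for compound 3, as the step of a 3.6-fold higher number from compound 2 to compound 3 (0.55 log units; beyond the scatter). The expected value for compound 3 in this assay is 5 nM, in the range 1.5 nM to 20 nM.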

Compound 3, half-maximal effective concentration: 3700 nM
Beside the measured number, compound 3's estimate is 740-fold (2.87 log units) below it; the measured number lies above the stated range.
By their numbers in this assay, from the lowest: compound 2; then compound 1; then compound 3.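

In this assay the exchange of one aromatic ring for another on the amide-type nitrogen gives a 2600-fold higher number from compound 2 to compound 3 (3.42 log units; beyond the scatter) and shows that the low number of compound 2 cannot be credited to an aromatic ring as such. Pyrimidin-2-yl in place of isopropyl gives a 53-fold higher number from compound 1 to compound 3 (1.72 log units; beyond the scatter) and places compound 3 behind the non-aromatic compound 1, so at this position an aromatic ring can also be worse than an alkyl group. The exchange changes ring size and hydrogen-bond donor count together, and nothing available explains the drop or tells these two changes apart.

Still open, as far as these compounds go, is whether the hydrogen on the pyrazole ring nitrogen matters, which a 1-methyl-1H-pyrazol-4-yl group would address. A pyridin-3-yl or phenyl group would show how six-membered rings behave at this position.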